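This account rests on a few compounds, and the source may have more. Where it says the series, first, only, none or still open, it means among the compounds named here.

Series notes. Compound 1 `O=C(O)CCSC(CCc1ccccc1-c1nc[nH]n1)c1cccc(OCc2ccc3ccc(Cl)cc3n2)c1` gives 0.36 nM in an assay on membranes from lung for binding affinity to cysteinyl leukotriene receptor 1 (Cavia porcellus); a higher number here means a weaker inhibitor, a lower number a stronger inhibitor. Compound 2 `CC(CCC(SCCC(=O)O)c1cccc(OCc2ccc3ccc(Cl)cc3n2)c1)CC(=O)N(C)C` gives 8.6 nM, and compound 3 `CN(C)C(=O)CCSC(SCCC(=O)O)c1cccc(OCc2ccc3ccc(Cl)cc3n2)c1` gives 14 nM; compound 3 thus shows the highest number of the three, though compound 2 sits within the scatter of it and only compound 1 lies well beyond it. Next, compound 4 `O=C(O)CCSC(CCc1ccccc1)c1cccc(OCc2ccc3ccc(Cl)cc3n2)c1` carries phenethyl in place of (2-(dimethylcarbamoyl)ethyl)sulfanyl on a saturated chain carbon bound to an aromatic carbon and a sulfur. Among the measured compounds shown here, two measured steps bear on this: a 1.6-fold higher number from compound 2 to compound 3 (0.21 log units; within the scatter), small, and a 24-fold higher number from compound 1 to compound 2 (1.38 log units; beyond the scatter), large, which shows the 2-(1H-1,2,4-triazol-3-yl)phenyl end favoured over an amide-bearing chain. Compound 4 carries phenethyl, which keeps the phenyl of that group but lacks the triazolyl. A downward step beyond the scatter is therefore expected, a 5.6-fold lower number from compound 3 to compound 4 (0.75 log units; beyond the scatter), placing compound 4 at an expected 2.5 nM with a range of 0.6 nM to 10 nM.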

Compound 4, half-maximal inhibitory concentration: 6.5 nM
Beside the measured number, compound 4's estimate is 2.6-fold (0.41 log units) below it; the measured number falls inside the stated range.
By their numbers in this assay, from the lowest: compound 1; then compounds 4, 2 and 3 (each within the scatter of the next, the first and the last beyond it).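

In this assay phenethyl in place of (2-(dimethylcarbamoyl)ethyl)sulfanyl gives a 2.2-fold lower number from compound 3 to compound 4 (0.33 log units; beyond the scatter) at this saturated chain carbon, so the amide is not needed there. Phenyl in place of 1-((dimethylcarbamoyl)methyl)ethyl gives a 1.3-fold lower number from compound 2 to compound 4 (0.12 log units; within the scatter) and separates neither end, while hydrogen in place of 1H-1,2,4-triazol-3-yl gives an 18-fold higher number from compound 1 to compound 4 (1.26 log units; beyond the scatter) and ties the low number of compound 1 to that ring. Nothing measured here explains these steps.

Open, as far as these compounds go, is whether a carboxylic acid or an amine on that aromatic carbon could stand in for 1H-1,2,4-triazol-3-yl. Also open, from the compounds shown here alone, is how a longer chain would read with the ring kept.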